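This account rests on a few compounds, and the source may have more. Where it says the series, first, only, none or still open, it means among the compounds named here.

Measured so far in an assay on isolated protein for inhibition of Maltase-glucoamylase (Homo sapiens); on this read-out higher numbers stand for weaker inhibition and lower numbers for stronger inhibition:
- compound 1 `COc1cc(C(c2c(O)c3cc(C)ccc3oc2=O)c2c(O)c3cc(C)ccc3oc2=O)cc(OC)c1OC`: 386000 nM
- compound 2 `O=c1oc2ccc(Cl)cc2c(O)c1C(c1cccc(O)c1)c1c(O)c2cc(Cl)ccc2oc1=O`: 84100 nM

Compound 2 holds the lower of the two numbers in this assay; the gap up to compound 1 lies beyond the scatter, so compound 2 reads as the stronger of the pair on this read-out. Among the measured compounds shown here, the two compounds differ in more than one place, so no single step can be drawn between them.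

Compound 3 `COc1cc(C(c2c(O)c3cc(Cl)ccc3oc2=O)c2c(O)c3cc(Cl)ccc3oc2=O)cc(OC)c1OC` is next for this assay. It departs from compound 2 by 3,4,5-trimethoxyphenyl in place of 3-hydroxyphenyl on a saturated chain carbon bound to two aromatic carbons, which brings in the aryl group already present in compound 1 while keeping the core of compound 2. For the measured compounds named here, with no measured step for this exact change, the expectation rests on compound 1 reading 386000 nM and compound 2 reading 84100 nM: the step is expected to go toward weaker inhibition, about a 2.6-fold higher number from compound 2 to compound 3 (0.42 log units; beyond the scatter), likely beyond the scatter. For compound 3 the estimate in this assay is 220000 nM, within 80000 nM to 600000 nM.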

Compound 3, half-maximal inhibitory concentration: 128000 nM
Estimate against measurement, compound 3: 1.7-fold (0.24 log units) above; low and high end bracket the measured number.
By their numbers in this assay, from the lowest: compounds 2 and 3 (each within the scatter of the next); then compound 1.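

In this assay the exchange of 3-hydroxyphenyl for 3,4,5-trimethoxyphenyl on a saturated chain carbon bound to two aromatic carbons gives a 1.5-fold higher number from compound 2 to compound 3 (0.18 log units; within the scatter) and so leaves compound 2 and compound 3 within the scatter of each other. This position therefore accepts a group of 12 heavy atoms with 0 hydrogen-bond donors and 3 hydrogen-bond acceptors in place of one of 7 heavy atoms with 1 of each, and no difference in inhibition can be read on this core. Nothing available accounts for the two compounds reading alike.

Still open, going by these compounds, is how an amine or a carboxylic acid on this aryl group would read in this assay on the same core. Equally open, on these data alone, is whether the same exchange would read alike on the core of compound 1.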